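The compounds below may be only part of what the source reports. "The series", "measured", "known", "first", "only" and "open" are said of these compounds alone.

Compound 1 `CN(C)CCNc1nc(-c2ccc(NC(=O)Nc3ccc(F)cc3)cc2)nc2ccsc12` gives 390 nM in a functional assay on NCI-H460 cells (Homo sapiens) for cytotoxicity, read by MTT assay, with a stated time of 72 h; a lower number here means a stronger inhibitor, a higher number a weaker inhibitor. Compound 2 `CN(C)CCNc1nc(-c2ccc(NC(=O)Nc3ccc(F)cc3)cc2)nc2c(Cl)c(Cl)sc12` carries a different core; the difference between the two cores is not broken down here. In this assay compound 2 gives 590 nM, a number within the usual scatter of compound 1 but beyond it from compound 3. Compound 3 `CN(C)CCNc1nc(-c2ccc(NC(=O)Nc3ccc(Cl)cc3)cc2)nc2ccsc12` keeps the core of compound 1 and differs from it by chloro in place of fluoro on an aromatic carbon. In this assay compound 3 gives 130 nM, so that the step of a 3.0-fold lower number from compound 1 to compound 3 (0.48 log units; beyond the scatter) is a modest one.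

Compound 4 `CN(C)CCNc1nc(-c2ccc(NC(=O)Nc3ccc(Cl)cc3)cc2)nc2c(Cl)c(Cl)sc12` differs from compound 2 by chloro in place of fluoro on an aromatic carbon, the same change at the same place, the second of its two occurrences among these four compounds. Because the step of a 3.0-fold lower number from compound 1 to compound 3 (0.48 log units; beyond the scatter) arose from this change on the other core, a step of like size is expected here, namely a 3.0-fold lower number from compound 2 to compound 4 (0.47 log units; beyond the scatter) in this assay. The only support for this expectation is that single pair of measured compounds. Compound 4 is therefore estimated at 200 nM, most likely between 100 nM and 450 nM.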

Compound 4, half-maximal inhibitory concentration: 300 nM
Beside the measured number, compound 4's estimate is 1.5-fold (0.18 log units) below it; the range from low to high includes it.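

In this assay, chloro in place of fluoro on the core of compound 2 gives a 2.0-fold lower number from compound 2 to compound 4 (0.29 log units; within the scatter), and this step does not differ from the one on the core of compound 1: the same change on two cores in this assay, a 3.0-fold lower number (0.48 log units; beyond the scatter) from compound 1 to compound 3 and a 2.0-fold lower number (0.29 log units; within the scatter) from compound 2 to compound 4, 1.5-fold (0.18 log units) apart, within the scatter of two such steps. Both steps point the same way, so the change from 4-fluorophenyl to 4-chlorophenyl carries over from one core to the other as far as these two pairs can tell, although the step on the core of compound 2 does not, taken alone, stand clear of the scatter. Two pairs on two cores do not make a rule for the series, and they do not show how the change would behave on any other core.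

The compounds shown leave open how bromo, methyl or trifluoromethyl would fare in place of the fluoro and the chloro. They also leave open whether the step would hold with a morpholine or a longer chain in place of the dimethylamino side chain.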